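Compound 3 set against two limit readings

A few compounds are considered here, and "the series" means these few. Any claim that something is new, unique, unknown or untested is made for them only; others in the source may bear on it.

Measured so far:
- compound 1 (`CC1c2c(-c3ccncc3)c(-c3ccccc3C#N)nn2CC1(C)C`): > 100000 nM as a limit
- compound 2 (`Cc1cccc(-c2nn3c(c2-c2ccnc(Cl)c2)CC(C)(C)C3)n1`): > 100000 nM as a limit

Both readings come from a functional assay on MCF7 cells (Homo sapiens) for cytotoxicity, with a stated time of 72 h (on this read-out higher numbers stand for weaker inhibition and lower numbers for stronger inhibition), and neither is a number. Compound 1 stands at the limit of > 100000 nM in this assay, at which 2 of the 2 values shown sit, and nothing firmer is known of it. Among the measured compounds shown here, compound 3 (`Cc1cccc(-c2nn3c(c2-c2ccncc2)C(C)C(C)(C)C3)n1`) keeps the core of compound 1 and carries 6-methylpyridin-2-yl in place of 2-cyanophenyl on an aromatic carbon as its one change. For the measured compounds named here, no measured step links these compounds, so the size of this change in this assay remains an expectation, with no shift beyond the scatter in either direction. Compound 2 also carries 6-methylpyridin-2-yl and reads > 100000 nM as a limit, which is the reason for expecting no gain. The expected change is a number no higher from compound 1 to compound 3 (the limit leaves the size open) and no more. The estimate for compound 3 is 100000 nM with an expected range of 40000 nM to 150000 nM and a reading at the limit is the likely outcome.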

Compound 3, half-maximal inhibitory concentration: > 100000 nM
Compound 3 was reported as a limit; the forecaster's own chance of this, stated with the estimate: 85%; the middle value lies on the limit itself.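

In this assay, among the compounds shown here, compound 1 and compound 3 both stand as limits and not numbers, and no step between them can be read. In this assay the compounds shown leave open whether 6-methylpyridin-2-yl in place of 2-cyanophenyl changes the reading at all, and at what concentration any of them would reach half-maximal inhibition.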